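Methyl on the pendant phenyl of compound 1

The source may hold more compounds than are shown below. What is called first, only, known or untested is meant among the compounds shown, and "the series" means these compounds.

Measured compounds in a functional assay on QG-56 cells (Homo sapiens) for antiproliferative activity; a higher number here means a weaker inhibitor, a lower number a stronger inhibitor:
- compound 1, `Cn1cncc1C(O)(c1ccc(C#N)cc1)c1cc2cc([N+](=O)[O-])cc(-c3ccccc3)c2o1`: 1480 nM
- compound 2, `COc1cccc(-c2cc(CO)cc3cc(C(O)(c4ccc(C#N)cc4)c4cncn4C)oc23)c1`: 16.8 nM
- compound 3, `Cn1cncc1C(O)(c1ccc([N+](=O)[O-])cc1)c1cc2cc([N+](=O)[O-])cc(-c3ccccc3)c2o1`: 547 nM

Compound 1 gives the highest number of the three; compound 3 stands nearest, and compound 2 lies far below it. For the measured compounds named here, the one single-point step recorded so far, a 2.7-fold lower number from compound 1 to compound 3 (0.43 log units; beyond the scatter), concerns a different part of the molecule and is modest in size.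

Compound 4, `Cc1cccc(-c2cc([N+](=O)[O-])cc3cc(C(O)(c4ccc(C#N)cc4)c4cncn4C)oc23)c1`, differs from compound 1 by methyl in place of hydrogen on an aromatic carbon. The change sits on the six-membered ring of carbon only, meta to a large group, and read one bond further out is phenyl to 3-methylphenyl. Going by the values given here, no measured pair isolates this change. Compound 2 also carries a substituent on that ring, but it differs from compound 1 in two further places, so its much lower number cannot be assigned to the ring substituent alone.

With a single added carbon and no change in donors, acceptors or charge, the step of a 1.3-fold lower number from compound 1 to compound 4 (0.13 log units; within the scatter) is expected to stay small, within or close to the scatter. Compound 4 is therefore estimated at 1100 nM, with a range from 400 nM to 3000 nM.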

Compound 4, half-maximal inhibitory concentration: 23.2 nM
The estimate for compound 4 lay 47-fold (1.68 log units) above the measured number; the measured number lies below the stated range.
By their numbers in this assay, from the lowest: compounds 2 and 4 (each within the scatter of the next); then compound 3; then compound 1.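

In this assay the pendant phenyl proves highly sensitive to substitution: phenyl to 3-methylphenyl gives a 64-fold lower number from compound 1 to compound 4 (1.80 log units; beyond the scatter) and is classed as large, although only one carbon enters, with no donor, acceptor or charge. The other single-place change from compound 1, nitro in place of cyano, gives a 2.7-fold lower number from compound 1 to compound 3 (0.43 log units; beyond the scatter) and is classed as modest, so among these compounds the aromatic ring carrying the methyl is the more responsive site. No available evidence bears on what lies behind this step.

As far as these compounds go, it remains open whether the drop depends on methyl itself or would also appear with ethyl, chlorine or an amine on this ring. It is equally unresolved whether the same methyl would give a step of similar size on compound 3, which carries nitro in place of cyano.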